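Fluoro for Bromo: Expected Tolerance on Vero Cells

The source may report more compounds than this note shows. Statements on the series, on what has been measured and on what is new or still open speak of the compounds shown alone.

The measured compounds:
- Compound 1, `CCCOc1ccc(C(=O)/C=C/c2ccc(C(=O)O)cc2)cc1`: in an ADME assay on Vero cells (Chlorocebus sabaeus) for cytotoxicity, read by MTT assay, with a stated time of 72 h (a lower number here means that less compound is tolerated, a higher number that more compound is tolerated), compound 1 gives < 10 ug/mL, which is a limit of the assay rather than a number.
- Compound 2, `COC(=O)c1cc(-c2cccc(NC(=O)c3ccc(/C=C/C(=O)c4ccc(Br)cc4)cc3)c2)on1`: in this assay compound 2 gives > 20 ug/mL, again a limit rather than a number.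
- Compound 3, `CCOC(=O)c1cc(-c2cccc(NC(=O)c3ccc(/C=C/C(=O)c4ccc(Cl)cc4)cc3)c2)on1`: in this assay compound 3 gives > 80 ug/mL, also a limit rather than a number.

Going by the values given here, none of these three values is an exact number, so no measured step between them can be stated. Compound 2 stands at the limit of > 20 ug/mL in this assay, at which 1 of the 3 values shown sits, while compound 1 sits at the limit of < 10 ug/mL in this assay, at which 1 of the 3 values shown sits, and compound 3 at the limit of > 80 ug/mL in this assay, at which 1 of the 3 values shown sits. The shared core of compound 2 and compound 3 is tolerated at least up to the limit reported for each.

Compound 4, `COC(=O)c1cc(-c2cccc(NC(=O)c3ccc(/C=C/C(=O)c4ccc(F)cc4)cc3)c2)on1`, has not yet been measured. It differs from compound 2 in one place: fluoro in place of bromo on an aromatic carbon. Among the compounds shown, a related halogen swap on the same ring accompanies compound 3, and its value is also a limit.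

Among the compounds with values here, with no measured step to lean on, the expected change in this assay is small, with no direction beyond the scatter. The step from compound 2 to compound 4 is therefore expected to be a step that the limit leaves unreadable from compound 2 to compound 4. Compound 4 is estimated to give 40 ug/mL, within a range from 15 ug/mL to 120 ug/mL.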

Compound 4, half-maximal cytotoxic concentration: > 20 ug/mL
Compound 4 was reported as a limit; the forecaster's own chance of this, stated with the estimate: 70%; the middle value does not contradict the limit.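

In this assay, compound 2 and compound 4 are each reported only as a limit, not a number: the limit of > 20 ug/mL in this assay, at which 2 of the 4 values shown sit. The step between these two compounds therefore cannot be read. The compounds shown leave open how much of either compound is tolerated, and whether fluoro in place of bromo changes that tolerance at all.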